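Methyl Added to a Chloropyridinyl Ether: Exposure Outlook

The source may report more compounds than this note shows. Statements on the series, on what has been measured and on what is new or still open speak of the compounds shown alone.

Compound 1, `Cc1ccc(Oc2ccc3nc(COc4cccc(C(=O)O)c4)n(C)c3n2)cc1`, gives 2520 ng.h/mL in an ADME assay on the whole organism (strain Zucker) for pharmacokinetics, with Rattus norvegicus as the target, with stated times of 24 h and 14 days, at a dose of 3 mg/kg by the oral route; on this read-out lower numbers stand for lower exposure and higher numbers for higher exposure at the dose given.
Compound 2, `Cn1c(COc2cccc(C(=O)O)c2)nc2ccc(Oc3ccc4c(c3)CCC4)nc21`, gives 4080 ng.h/mL in this assay.
Compound 3, `Cn1c(COc2cccc(C(=O)O)c2)nc2ccc(Oc3ccc(Cl)cn3)cc21`, gives 1010 ng.h/mL in this assay.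

Compound 3 stands lowest of these three in this assay; the gap to compound 1 and the larger gap to compound 2 both lie beyond the usual scatter of this read-out. Compound 4, `Cc1cc(Cl)cnc1Oc1ccc2nc(COc3cccc(C(=O)O)c3)n(C)c2c1`, has not yet been measured. It differs from compound 3 by methyl in place of hydrogen on an aromatic carbon.

Among the measured compounds shown here, the only measured step with a single structural change is a 1.6-fold higher number from compound 1 to compound 2 (0.21 log units; within the scatter), and that step swaps one whole aryl group on the ether oxygen for another; it does not touch a small substituent on a pyridine ring, so it says nothing direct about adding a methyl. For the measured compounds named here, no measured pair here shows what a methyl on this ring does to exposure. With nothing that bears on the change, the expectation for compound 4 in this assay is a step of about a 1.1-fold higher number from compound 3 to compound 4 (0.04 log units; within the scatter), that is, no change beyond the scatter in either direction. Compound 4 is therefore estimated at 1100 ng.h/mL, with a range from 400 ng.h/mL to 3000 ng.h/mL.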

Compound 4, area under the concentration-time curve: 1250 ng.h/mL
Beside the measured number, compound 4's estimate is 1.1-fold (0.06 log units) below it, and the stated range covers the measured number.
By their numbers in this assay, from the lowest: compounds 3, 4, 1 and 2 (each within the scatter of the next, the first and the last beyond it).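

In this assay, among the compounds shown here, exchanging 5-chloropyridin-2-yl for 5-chloro-3-methylpyridin-2-yl on the ether oxygen gives a 1.2-fold higher number from compound 3 to compound 4 (0.09 log units; within the scatter), the first direct look at what a methyl does at this place on the ring: ortho to a large group, two atoms from the ring nitrogen and meta to the chloro group. The earlier compounds shown here offered only an exchange of one whole aryl group for another, whereas this pair isolates a single added carbon, and the two exposure numbers cannot be told apart, so this position accepts a methyl with no readable effect on this read-out. Nothing available here speaks to what lies behind this result.

Still open, from the compounds shown here alone, is whether a group other than methyl at this same position, such as an ethyl, a methoxy or an amine, would also leave the number within the scatter or would move it clearly up or down. Also open, going by these compounds, is whether the same methyl would behave this way on the core of compound 1, where the ether oxygen carries a different aryl group.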